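A few compounds are considered here, and "the series" means these few. Any claim that something is new, unique, unknown or untested is made for them only; others in the source may bear on it.

Compound 1 `O=C(C1=C(O)C(=O)N(CCCn2ccnc2)C1c1ccc(Br)cc1)c1ccccc1` gives 20000 nM in a functional assay on NCI-H1299 cells (Homo sapiens) for antiproliferative activity, read by MTT assay, with a stated time of 72 h; on this read-out lower numbers stand for stronger inhibition and higher numbers for weaker inhibition.
Compound 2 `NC1=C(C(=O)c2ccccc2)C(c2ccc(Br)cc2)N(CCCn2ccnc2)C1=O` gives 169000 nM in this assay.
Compound 3 `O=C(C1=C(Nc2ccc(Br)cc2)C(=O)N(CCCn2ccnc2)C1c1ccc(Br)cc1)c1ccccc1` gives 19300 nM in this assay.

Among these three, compound 3 has the lowest number, but compound 1 sits within the usual scatter of it, so the two cannot be ranked against each other; only compound 2 stands clearly apart, as the step of an 8.8-fold lower number from compound 2 to compound 3 (0.94 log units; beyond the scatter) shows.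

Compound 4 `O=C(C1=C(Nc2ccccc2Br)C(=O)N(CCCn2ccnc2)C1c1ccc(Br)cc1)c1ccccc1` has not yet been measured. It differs from compound 3 in one place: 2-bromophenyl in place of 4-bromophenyl on an amine nitrogen. The bromine thus stays on the ring attached to the amine nitrogen but moves to another position on that ring.

Going by the values given here, two measured steps touch the group at this nitrogen. The step of a 1.0-fold lower number from compound 1 to compound 3 (0.02 log units; within the scatter) shows that replacing hydroxy with (4-bromophenyl)amino left the number essentially unchanged, and an 8.8-fold lower number from compound 2 to compound 3 (0.94 log units; beyond the scatter) shows that putting the 4-bromophenyl onto the amine nitrogen in place of hydrogen lowered the number modestly. Among the compounds with values here, neither step moves the bromine around the ring, so no measured pair speaks directly to the change from compound 3 to compound 4. With the ring itself and its bromine retained, the expectation is for no step beyond the scatter in this assay.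

Compound 4 is therefore estimated at 22000 nM, within a range of 8000 nM to 60000 nM, which corresponds to an expected step of a 1.1-fold higher number from compound 3 to compound 4 (0.06 log units; within the scatter).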

Compound 4, half-maximal inhibitory concentration: 15600 nM
For compound 4 the middle estimate is 1.4-fold (0.15 log units) above the measured one, and the stated range covers the measured number.
By their numbers in this assay, from the lowest: compounds 4, 3 and 1 (each within the scatter of the next); then compound 2.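

Moving the bromine from 4-bromophenyl to 2-bromophenyl on the amine nitrogen gives a 1.2-fold lower number from compound 3 to compound 4 (0.09 log units; within the scatter) in this assay, so this pair shows no readable dependence on where the bromine sits on that ring. Until now the gain over the free amino group rested on the 4-bromophenyl alone; the step of an 11-fold lower number from compound 2 to compound 4 (1.03 log units; beyond the scatter) shows that a second bromophenyl arrangement also stands clearly apart from compound 2. Against the hydroxy group, the result of a 1.3-fold lower number from compound 1 to compound 4 (0.11 log units; within the scatter) matches what compound 3 showed, so neither (4-bromophenyl)amino nor (2-bromophenyl)amino can be told apart from hydroxy at this ring carbon, and no measurement shown here bears on why the bromine's place makes no readable difference.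

The compounds shown leave open whether the bromine is needed at all, as none of them has a plain phenyl on this nitrogen. Going by these compounds, it also remains open whether a pyridyl or a cyclohexyl group there would hold the number near those of compound 3 and compound 4, or whether either would move it clearly away from them.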